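Compound 3 after a modest step at the sulfur

A few compounds are considered here, and "the series" means these few. Any claim that something is new, unique, unknown or untested is made for them only; others in the source may bear on it.

Measured in a functional assay on A549 cells (Homo sapiens) for inhibition, read by CCK-8 assay, with a stated time of 72 h, tested at 8 uM; on this read-out higher numbers stand for more inhibition of growth at the one concentration tested and lower numbers for less inhibition of growth:
- compound 1 `COc1ccc(SCc2ccc(/C=C/C(=O)Nc3ccccc3N)cc2)cc1OC` gives 80.6%
- compound 2 `Nc1ccccc1NC(=O)/C=C/c1ccc(CSc2cccc(F)c2)cc1` gives 56.6%

Of these two numbers, compound 2 is the lower at 56.6%, and the gap to compound 1 lies beyond the scatter. The next compound is compound 3 `Nc1ccccc1NC(=O)/C=C/c1ccc(CSc2ccc(C(F)(F)F)cn2)cc1`. The change is 5-(trifluoromethyl)pyridin-2-yl in place of 3-fluorophenyl on a sulfur.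

Going by the values given here, one measured step bears on this, as it changes the same place: a number 24 percentage points lower from compound 1 to compound 2 (beyond the scatter). This modest step shows that the group on the sulfur can move the number in this assay, but it sets no direction for the new group. Among the compounds with values here, no measured compound carries 5-(trifluoromethyl)pyridin-2-yl. No step beyond the scatter is therefore expected, with either direction open and a wide range. The expected step is a number 1.4 percentage points higher from compound 2 to compound 3 (within the scatter). For compound 3 the estimated value is 58%, with an expected range of 35% to 80%.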

Compound 3, percent growth inhibition at one concentration: 56.5%
Beside the measured number, compound 3's estimate is 1.5 percentage points above it; the range from low to high includes it.
By their numbers in this assay, from the lowest: compounds 3 and 2 (each within the scatter of the next); then compound 1.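

In this assay, exchanging 3-fluorophenyl on the sulfur for the larger 5-(trifluoromethyl)pyridin-2-yl, which brings a ring hetero atom and a hydrogen-bond acceptor, gives a number 0.1 percentage points lower from compound 2 to compound 3 (within the scatter), so this position tolerates that change in ring and substituent without a step that can be told from the scatter. Against the 3,4-dimethoxyphenyl group the new group gives a number 24.1 percentage points lower from compound 1 to compound 3 (beyond the scatter), so two quite different groups on the sulfur now stand apart from compound 1 by a similar margin, and the high number of compound 1 no longer rests on a comparison with a single group. No supporting data on these compounds accounts for the gap to compound 1 or for the match between compound 2 and compound 3.

As far as these compounds go, it remains open whether the number of compound 1 needs both methoxy groups, which a phenyl group with one methoxy group or a 3,4-dihydroxyphenyl group would test. Also open, from the compounds shown here alone, is how an amine or a carboxylic acid on this ring would read, and whether the steps seen at one concentration would hold across a range of concentrations.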